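Ring-hydroxyl position shifts growth inhibition in a thiosemicarbazone set

A few compounds are considered here, and "the series" means these few. Any claim that something is new, unique, unknown or untested is made for them only; others in the source may bear on it.

Compound 1 `CC1=CC[C@H](C(C)(C)NC(=S)N/N=C/c2ccccc2)CC1`: 67000 nM
Compound 2 `CC1=CC[C@H](C(C)(C)NC(=S)N/N=C/c2ccc(O)cc2)CC1`: > 100000 nM
Compound 3 `CC1=CC[C@H](C(C)(C)NC(=S)N/N=C/c2ccccc2O)CC1`: 12100 nM

Of the compounds shown here, three of one shared core have been measured in a functional assay on 786-0 cells (Homo sapiens) for inhibition, read by sulforhodamine B assay, with a stated time of 48 h; on this read-out higher numbers stand for weaker inhibition of growth and lower numbers for stronger inhibition of growth. Compound 1 carries a plain phenyl and gives 67000 nM. Compound 2 reaches only (the limit of > 100000 nM in this assay, at which 1 of the 3 values shown sits), which is a limit of the assay and not a number. Compound 3, with the hydroxy on a different aromatic carbon, gives 12100 nM and stands lowest of the two numbers that are known; the nearest is compound 1, reached by a 5.5-fold lower number from compound 1 to compound 3 (0.74 log units; beyond the scatter). The other two steps run the opposite way: an at least 1.4-fold higher number from compound 1 to compound 2 (0.17 log units; that floor lies within the scatter) and an at least 8.2-fold lower number from compound 2 to compound 3 (0.91 log units; beyond the scatter).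

Compound 4 `CC1=CC[C@H](C(C)(C)NC(=S)N/N=C/c2ccc(F)cc2)CC1` has not yet been measured. It differs from compound 3 by 4-fluorophenyl in place of 2-hydroxyphenyl on a carbon with a double bond to nitrogen. Among the compounds with values here, no measured step covers a fluorine; the nearest guides are the plain phenyl of compound 1 and the 4-hydroxyphenyl of compound 2, which both sit well above compound 3. Compound 4 is therefore expected to lose most of what compound 3 shows, a step estimated at a 5.0-fold higher number from compound 3 to compound 4 (0.70 log units; beyond the scatter). The estimate for compound 4 in this assay is 60000 nM, within a range from 20000 nM to 180000 nM.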

Compound 4, concentration for total growth inhibition: > 100000 nM
Compound 4 gave a limit, no number (the forecaster's own chance of this, stated with the estimate: 30%); middle value at least 1.6-fold (0.22 log units) from the limit.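

Compound 4 ends at a limit of the assay and not at a number, as compound 2 does: the limit of > 100000 nM in this assay, at which 2 of the 4 values shown sit.

In this assay, the change of group on the carbon with a double bond to nitrogen gives an at least 8.2-fold higher number from compound 3 to compound 4 (0.91 log units; beyond the scatter), so a second group besides 4-hydroxyphenyl now falls well short of the 2-hydroxyphenyl of compound 3, and that group carries fluorine, with no hydrogen-bond donor or acceptor. Against the plain phenyl the result is less firm, with an at least 1.4-fold higher number from compound 1 to compound 4 (0.17 log units; that floor lies within the scatter), and the step between the two limits cannot be read, so fluoro cannot be ranked against either hydrogen or hydroxy on this ring.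

Going by these compounds, what a 2-methoxyphenyl, a 2-aminophenyl or a 2-fluorophenyl would give on the same carbon stays open, and with it whether the lower number of compound 3 rests on the hydroxy itself or on any group in that place. Also open, on these data alone, is how far compound 2 and compound 4 lie beyond their limits, and whether either differs from the other at all.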